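This account rests on a few compounds, and the source may have more. Where it says the series, first, only, none or still open, it means among the compounds named here.

Of the compounds shown here, three built on one shared core have been measured in an assay on isolated protein for displacement of a labelled ligand from metabotropic glutamate receptor 5 (Homo sapiens), with a stated time of 60 min, tested at 1 uM; a lower number here means less inhibition, a higher number more inhibition at the concentration tested (going by the name of the read-out). Compound 1 `COc1ccc(S(=O)(=O)c2cnc3c(F)cccc3c2N2CCC(C)CC2)cc1` gives 67%. Compound 2 `CC1CCN(c2c(S(=O)(=O)c3ccc(Cl)c(Cl)c3)cnc3c(F)cccc23)CC1` gives 95%, and compound 3 `CC1CCN(c2c(S(=O)(=O)c3ccc(F)c(Cl)c3)cnc3c(F)cccc23)CC1` gives 95%. Compound 3 thus stands level with compound 2 as reported, the two together the highest of the three numbers, and the step of no change at the digits printed from compound 2 to compound 3 (within the scatter) lies within the scatter. Against compound 1 the gap is wider: a number 28 percentage points higher from compound 1 to compound 3 (beyond the scatter), and likewise a number 28 percentage points higher from compound 1 to compound 2 (beyond the scatter).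

Compound 4 `CC1CCN(c2c(S(=O)(=O)c3ccc(F)cc3)cnc3c(F)cccc23)CC1` has not yet been measured. It differs from compound 3 in one place: hydrogen in place of chloro on an aromatic carbon. The chloro that leaves sits on an aromatic carbon ortho to a fluoro group, and the same difference read one bond further out is 3-chloro-4-fluorophenyl to 4-fluorophenyl. Among the compounds with values here, no measured step removes a group in this way. Within the data shown here, the nearest precedent is the exchange of chloro for fluoro on an aromatic carbon, no change at the digits printed from compound 2 to compound 3 (within the scatter), which left the number unchanged, while the larger replacements in a number 28 percentage points higher from compound 1 to compound 2 (beyond the scatter) and a number 28 percentage points higher from compound 1 to compound 3 (beyond the scatter) show that the whole aryl group on the sulfonyl sulfur does matter. A modest fall in this assay is therefore expected, a number 13 percentage points lower from compound 3 to compound 4 (beyond the scatter), though a result within the scatter would not surprise. For compound 4 the estimated value is 82%, with a range from 62% to 95%.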

Compound 4, a percentage reported as inhibition, at one concentration (the size of the read-out at that concentration, not a potency): 26%
Compound 4: the middle estimate sits 56 percentage points above what was measured; the measured number lies below the stated range.
By their numbers in this assay, from the lowest: compound 4; then compound 1; then compounds 2 and 3 (each within the scatter of the next).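

The chloro kept in both compound 2 and compound 3 turns out to matter far more in this assay than the exchange between those two compounds suggested: that exchange touched the other halogen, whereas hydrogen in place of this chloro gives a number 69 percentage points lower from compound 3 to compound 4 (beyond the scatter). Seen from the 3,4-dichlorophenyl group, the change to 4-fluorophenyl gives a number 69 percentage points lower from compound 2 to compound 4 (beyond the scatter), and fluoro in place of methoxy gives a number 41 percentage points lower from compound 1 to compound 4 (beyond the scatter), so a halogen on the aryl group does not by itself raise the number, and among these compounds the high values belong to the two that carry this chloro. Nothing reported for these compounds accounts for the loss.

The compounds shown leave open whether a bromo, a methyl or a nitrile on that carbon would keep the number high, and whether a 3-chlorophenyl group, with the chloro but no fluoro, would be enough. From the compounds shown here alone, a read-out at a single concentration is also not a potency, so how compound 2 and compound 3 compare in potency remains unknown.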